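A few compounds are considered here, and "the series" means these few. Any claim that something is new, unique, unknown or untested is made for them only; others in the source may bear on it.

In a functional assay on HT-29 cells (Homo sapiens) for inhibition (on this read-out higher numbers stand for weaker inhibition and lower numbers for stronger inhibition), compound 1 `Oc1ccc(/C=C/c2ccc3ccccc3c2)cc1` gives 4060 nM. Compound 2 `COc1ccc(/C=C/c2ccc3ccccc3c2)cc1` reads > 5000 nM, which is a limit and not a number. Compound 3 `FC(F)(F)Oc1ccc(/C=C/c2ccc3ccccc3c2)cc1` reads > 5000 nM, which is likewise a limit. Compound 3 therefore stands at the limit of > 5000 nM in this assay, at which 2 of the 3 values shown sit.

Compound 4 `Cc1ccc(/C=C/c2ccc3ccccc3c2)cc1` follows from compound 3 through (methyl in place of trifluoromethoxy on an aromatic carbon), with methyl in place of trifluoromethoxy on an aromatic carbon, para to a large group.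

The measured steps closest to this change are an at least 1.2-fold higher number from compound 1 to compound 2 (0.09 log units; that floor lies within the scatter) and an at least 1.2-fold higher number from compound 1 to compound 3 (0.09 log units; that floor lies within the scatter). A third step, a step that the two limits leave unreadable from compound 2 to compound 3, adds no size. All three alter only the group on the oxygen, whereas compound 4 has no oxygen at that place, so they bear on the change only indirectly. None of them shows a step beyond the scatter, and none is expected in this assay here. The estimated step is a number no higher from compound 3 to compound 4 (the limit leaves the size open), and a further limit is a likely outcome. For compound 4 the estimated value is 5000 nM, with an expected range of 2500 nM to 10000 nM.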

Compound 4, half-maximal inhibitory concentration: > 5000 nM
Compound 4 was reported as a limit; the forecaster's own chance of this, stated with the estimate: 55%; the middle value sits exactly at the limit.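

In this assay compound 4 gives > 5000 nM, which is a limit and not a number. Among these compounds, removing the oxygen at this place, with methyl on the aromatic carbon, therefore yields no readable value either: the steps from compound 2 and compound 3 to compound 4 cannot be read, and the only step that can be stated is an at least 1.2-fold higher number from compound 1 to compound 4 (0.09 log units; that floor lies within the scatter). Compound 1, with its hydroxy, remains the only compound here with a number, and the other three now share one limit: the limit of > 5000 nM in this assay, at which 3 of the 4 values shown sit.

The limits leave open how far compound 2, compound 3 and compound 4 actually lie from compound 1. Also open, going by these compounds, is whether an amine or a carboxylic acid at this place would give a value clearly separated from that of compound 1.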